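The compounds below may be only part of what the source reports. "The series", "measured", "known", "first", "only" and "open" are said of these compounds alone.

Measured compounds:
Compound 1 `O=C(O)Cc1sc(C(c2ccc(F)cc2)c2ccc(F)cc2)nc1-c1cccc(F)c1` — 80%
Compound 2 `O=C(O)Cc1sc(C(c2ccc(F)cc2)c2ccc(F)cc2)nc1-c1ccc(Cl)cc1` — 80%
Compound 3 `Nc1cc(-c2nc(C(c3ccc(F)cc3)c3ccc(F)cc3)sc2CC(=O)O)cc(F)n1` — 30%

In an in vitro functional assay on HEK285-7 cells for antagonist activity at prostaglandin D2 receptor 2 (Homo sapiens), read by BRET and beta-arrestin recruitment (on this read-out lower numbers stand for smaller maximal responses and higher numbers for larger maximal responses), compound 3 gives 30%, the lowest of the three numbers; compound 1 and compound 2 each stand higher, and both gaps are beyond the scatter. The step to compound 4 `CN(C)c1cc(-c2nc(C(c3ccc(F)cc3)c3ccc(F)cc3)sc2CC(=O)O)ccn1` is 2-(dimethylamino)pyridin-4-yl in place of 2-amino-6-fluoropyridin-4-yl on an aromatic carbon. Among the measured compounds shown here, no measured step changes one pyridinyl for another, so the nearest comparisons are a number 50 percentage points lower from compound 1 to compound 3 (beyond the scatter) and a number 50 percentage points lower from compound 2 to compound 3 (beyond the scatter), which show that exchanging a phenyl for the aminofluoropyridinyl lowers the maximal response strongly, while no change at the digits printed from compound 1 to compound 2 (within the scatter) shows that exchanging one phenyl for another leaves it unchanged. For the measured compounds named here, compound 4 keeps a pyridinyl at the same place and alters only its substituents, so the response is expected to stay in the lower region set by compound 3, with some movement upward left open; no measured step covers the new group. Compound 4 is therefore expected to give 40%, between 20% and 65%, meaning an expected step of a number 10 percentage points higher from compound 3 to compound 4 (within the scatter).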

Compound 4, largest response reached (reported as efficacy), in percent of the reference or control that the assay uses: 80%
For compound 4 the middle estimate is 40 percentage points below the measured one; the whole stated range lies below it.
By their numbers in this assay, from the lowest: compound 3; then compounds 1, 2 and 4 (each within the scatter of the next).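

In this assay, 2-(dimethylamino)pyridin-4-yl in place of 2-amino-6-fluoropyridin-4-yl gives a number 50 percentage points higher from compound 3 to compound 4 (beyond the scatter), so a pyridinyl at this place does not by itself keep the maximal response low. Set against the phenyl compounds, the same group gives no change at the digits printed from compound 2 to compound 4 (within the scatter) and no change at the digits printed from compound 1 to compound 4 (within the scatter), which puts it level with both 4-chlorophenyl and 3-fluorophenyl. The substituents on the pyridinyl ring therefore decide the response here, and among these four compounds only compound 3 stands apart.

No measurement shown explains this difference. The exchange alters the amine and removes the fluorine together, leaving open how a pyridinyl with an unsubstituted amine and no fluorine, or with a dimethylamino group and a fluorine, would respond.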